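This account rests on a few compounds, and the source may have more. Where it says the series, first, only, none or still open, it means among the compounds named here.

Three analogues on a shared core differ only in the aryl group carried on an oxygen on an aromatic ring. Compound 1, `Cc1nn(C)c(Oc2ccccc2F)c1/C=N\CCCCCCOc1cc2oc(=O)cc(C)c2cc1Cl`, bears a 2-fluorophenyl there; in a functional assay on HepG2 cells (Homo sapiens) for antiproliferative activity, read by MTT assay, with a stated time of 72 h (a higher number here means a weaker inhibitor, a lower number a stronger inhibitor), compound 1 reaches only the limit of > 25000 nM, so no number is known for it. Compound 2, `Cc1nn(C)c(Oc2ccc(F)cc2)c1/C=N\CCCCCCOc1cc2oc(=O)cc(C)c2cc1Cl`, carries a 4-fluorophenyl, and in this assay compound 2 gives 12500 nM. Compound 3, `Cc1nn(C)c(Oc2ccc(I)cc2)c1/C=N\CCCCCCOc1cc2oc(=O)cc(C)c2cc1Cl`, carries a 4-iodophenyl, and in this assay compound 3 gives 14200 nM, the higher of the two numbers, although the step of a 1.1-fold higher number from compound 2 to compound 3 (0.06 log units; within the scatter) lies within the scatter. The two steps away from the 2-fluorophenyl, an at least 2.0-fold lower number from compound 1 to compound 2 (0.30 log units; that floor lies within the scatter) and an at least 1.7-fold lower number from compound 1 to compound 3 (0.24 log units; that floor lies within the scatter), each have a floor that lies within the scatter.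

Compound 4, `Cc1ccccc1Oc1c(/C=N\CCCCCCOc2cc3oc(=O)cc(C)c3cc2Cl)c(C)nn1C`, differs from compound 3 by 2-methylphenyl in place of 4-iodophenyl on an oxygen on an aromatic ring. For the measured compounds named here, the steps that bear on this change are the two in which a 2-fluorophenyl gave way to a 4-fluorophenyl or a 4-iodophenyl, and both ran toward lower numbers with the substituent in the 4-position. Returning a substituent to the 2-position of the phenyl is therefore expected to move the number upward by about a 1.5-fold higher number from compound 3 to compound 4 (0.19 log units; within the scatter). Compound 4 is accordingly estimated at 22000 nM, within a range from 9000 nM to 60000 nM, with a fair chance that only a limit is reported.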

Compound 4, half-maximal inhibitory concentration: 7830 nM
Compound 4: the middle estimate sits 2.8-fold (0.45 log units) above what was measured; measured number below the stated range.
By their numbers in this assay, from the lowest: compounds 4, 2 and 3 (each within the scatter of the next). At a limit, above all of these: compound 1.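

In this assay, for the compounds shown here, the 2-methylphenyl of compound 4 does not go with the 2-fluorophenyl of compound 1: methyl in place of fluoro gives an at least 3.1-fold lower number from compound 1 to compound 4 (0.50 log units; beyond the scatter), the first step in this set printed as beyond the scatter. Against the 4-iodophenyl and 4-fluorophenyl analogues no separation appears, with a 1.8-fold lower number from compound 3 to compound 4 (0.26 log units; within the scatter) and a 1.6-fold lower number from compound 2 to compound 4 (0.20 log units; within the scatter), so among these compounds a substituent at that place on the phenyl does not by itself hold the number up. The step from compound 1 rests on a limit, not on a number: the limit of > 25000 nM in this assay, at which 1 of the 4 values shown sits.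

The compounds shown leave open how a 4-methylphenyl or an unsubstituted phenyl would compare with the 2-methylphenyl. They also leave open whether a methoxy group or a chloro group at that place would follow methyl or fluoro.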